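Fluoro for methyl on an orexin receptor antagonist

A few compounds are considered here, and "the series" means these few. Any claim that something is new, unique, unknown or untested is made for them only; others in the source may bear on it.

Compound 1 `Cc1ccc(-n2nccn2)c(C(=O)N2CCCO[C@H]2Cc2noc(-c3ccc(F)cn3)n2)c1`: 4.54 nM
Compound 2 `O=C(c1ccccc1-n1nccn1)N1CCCO[C@H]1Cn1ccc(-c2ccc(F)cn2)n1`: 3.76 nM
Compound 3 `Cc1ccc(-c2ncccn2)c(C(=O)N2CCCO[C@H]2Cn2ccc(-c3ccc(F)cn3)n2)c1`: 3.29 nM

All three compounds were tested in a functional assay on CHO-K1 cells for antagonist activity at Orexin/Hypocretin receptor type 1 (Homo sapiens), read by fluorescence and calcium flux, with a stated time of 30 min; a higher number here means a weaker inhibitor, a lower number a stronger inhibitor. Compound 1 gives 4.54 nM, compound 2 gives 3.76 nM, and compound 3 gives 3.29 nM. The three numbers sit close together: that of compound 3 is the smallest, but its gap to compound 2 and its gap to compound 1 both lie within the scatter of repeated measurements, so no order among them can be claimed.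

Compound 4 `O=C(c1cc(F)ccc1-c1ncccn1)N1CCCO[C@H]1Cn1ccc(-c2ccc(F)cn2)n1` is not yet measured. It differs from compound 3 in one place: fluoro in place of methyl on an aromatic carbon. Among the measured compounds shown here, no pair of measured compounds differing in exactly one place is available, so the step cannot be read off from the data. The shared core and the remaining groups are unchanged, and the three measured compounds, which differ in other places, all land in a narrow band.

For that reason the step from compound 3 to compound 4 in this assay is expected to be small, a 1.1-fold higher number from compound 3 to compound 4 (0.03 log units; within the scatter), in no firm direction and probably within the scatter. Compound 4 is therefore estimated at 3.5 nM, with a range from 1.5 nM to 8 nM.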

Compound 4, half-maximal inhibitory concentration in the Orexin/Hypocretin receptor type 1 assay: 3.22 nM
For compound 4 the middle estimate is 1.1-fold (0.04 log units) above the measured one, within the range that was stated.
By their numbers in the Orexin/Hypocretin receptor type 1 assay, from the lowest: compounds 4, 3, 2 and 1 (each within the scatter of the next).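

Among the compounds shown here, for the first time in this set, two compounds differ in one place only, so a single change can be read directly: fluoro in place of methyl on an aromatic carbon, para to a pyrimidin-2-yl group, which in the Orexin/Hypocretin receptor type 1 assay gives a 1.0-fold lower number from compound 3 to compound 4 (0.01 log units; within the scatter). In the Orexin/Hypocretin receptor type 1 assay compound 3 gives 3.29 nM and compound 4 gives 3.22 nM. In a physicochemical assay for lipophilicity, read by HPLC, at pH 7.4 (a higher number here means a more lipophilic compound, a lower number a more polar compound), compound 3 gives 2.36 and compound 4 gives 2.3. In the physicochemical assay the same change gives a number 0.06 log units lower from compound 3 to compound 4 (within the scatter), so at this position, on this core, the two groups cannot be told apart in either read-out. No measurement among those shown offers an explanation for this result.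

Methyl and fluoro are both single small substituents, so the pair says little about how much freedom this position really has, and a methoxy group, a carboxylic acid or an amine placed there could give a quite different result in either assay. From the compounds shown here alone, it also remains open whether the same swap would read the same way on the related compounds, such as compound 1, where other parts of the molecule differ.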